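Nitrophenyl position: from compound 3 to compound 4

A few compounds are considered here, and "the series" means these few. Any claim that something is new, unique, unknown or untested is made for them only; others in the source may bear on it.

- compound 1 `COc1ccc(/C=C(\C#N)C(=O)N/N=C(\C)c2c(O)c3ccc(O)cc3oc2=O)cc1` gives 96100 nM
- compound 2 `C/C(=N\NC(=O)/C(C#N)=C/c1cccc([N+](=O)[O-])c1)c1c(O)c2ccc(O)cc2oc1=O` gives 46500 nM
- compound 3 `C/C(=N\NC(=O)/C(C#N)=C/c1ccc([N+](=O)[O-])cc1)c1c(O)c2ccc(O)cc2oc1=O` gives 43200 nM

In a functional assay on NRK-49F cells (Rattus norvegicus) for cytotoxicity, read by MTT assay, with a stated time of 24 h (on this read-out lower numbers stand for stronger inhibition and higher numbers for weaker inhibition), compound 3 and compound 2 sit together at the low end of the three numbers, with no separation beyond the scatter (a 1.1-fold lower number from compound 2 to compound 3 (0.03 log units; within the scatter)). Both lie under compound 1 (a 2.1-fold lower number from compound 1 to compound 2 (0.32 log units; beyond the scatter); a 2.2-fold lower number from compound 1 to compound 3 (0.35 log units; beyond the scatter)). These are modest steps, and each replaces a methoxy-bearing aryl group with a nitro-bearing one.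

Compound 4 (`C/C(=N\NC(=O)/C(C#N)=C/c1ccccc1[N+](=O)[O-])c1c(O)c2ccc(O)cc2oc1=O`) has the same atoms as compound 3, joined differently (2-nitrophenyl in place of 4-nitrophenyl on a double-bonded chain carbon bound to a double-bonded chain carbon): 2-nitrophenyl in place of 4-nitrophenyl on a double-bonded chain carbon bound to a double-bonded chain carbon. Within the data shown here, the closest precedent is the shift of the nitro group between compound 2 and compound 3 (a 1.1-fold lower number from compound 2 to compound 3 (0.03 log units; within the scatter)). The steps from compound 1 bear less directly, since compound 4 keeps the nitro group. Among the measured compounds shown here, no compound carrying 2-nitrophenyl has been measured, so the precedent is a single comparison that does not cover this placement. In this assay no step beyond the scatter is expected, in either direction. The step estimated here is a 1.0-fold higher number from compound 3 to compound 4 (0.02 log units; within the scatter) and it is expected to stay within the scatter. For compound 4 the expected value is 45000 nM with an estimated range from 22000 nM to 92000 nM in this measurement.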

Compound 4, half-maximal inhibitory concentration: 68600 nM
Compound 4: the middle estimate sits 1.5-fold (0.18 log units) below what was measured, and the stated range covers the measured number.
By their numbers in this assay, from the lowest: compounds 3, 2, 4 and 1 (each within the scatter of the next, the first and the last beyond it).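

In this assay the 2-nitrophenyl group completes the set of nitro placements on this aryl group, and neither a 1.6-fold higher number from compound 3 to compound 4 (0.20 log units; within the scatter) nor a 1.5-fold higher number from compound 2 to compound 4 (0.17 log units; within the scatter) leaves the scatter, so the three placements cannot be told apart on this read-out. The earlier separation of the nitro-bearing compounds from the 4-methoxyphenyl compound does not extend to this placement: a 1.4-fold lower number from compound 1 to compound 4 (0.15 log units; within the scatter) stays within the scatter, while compound 2 and compound 3 lie beyond it from compound 1, so carrying a nitro group on this aryl group does not in itself give a step beyond the scatter. No measured finding at hand accounts for any of these steps.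

The compounds shown leave open whether a different group on this aryl ring, such as an amine or a carboxylic acid in place of the nitro group, would move the number beyond the scatter from compound 3. They also leave open whether a plain phenyl group on a double-bonded chain carbon bound to a double-bonded chain carbon would read with the nitro compounds or with compound 1.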